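Propargylic alcohols as 5-lipoxygenase inhibitors: methoxy for fluoro

The source may hold more compounds than are shown below. What is called first, only, known or untested is meant among the compounds shown, and "the series" means these compounds.

Measured so far:
compound 1, `CSc1ccc(COCC#CC(O)c2ccc(F)cc2)cc1` — 12000 nM
compound 2, `COc1cc(C(O)C#CCOCc2ccc(SC)cc2)cc(OC)c1OC` — 80000 nM
compound 3, `OC(C#CCOCc1ccccc1)c1ccccc1` — > 100000 nM

In an assay on isolated protein for inhibition of Polyunsaturated fatty acid 5-lipoxygenase (Homo sapiens) (a lower number here means a stronger inhibitor, a higher number a weaker inhibitor), compound 1 gives 12000 nM and holds the lower of the two numbers recorded; compound 2, at 80000 nM in this assay, sits beyond the usual scatter of compound 1. For compound 3 this assay reports only a limit, > 100000 nM, not a number; this is the limit of > 100000 nM in this assay, at which 1 of the 3 values shown sits. Within the data shown here, no pair of compounds that differ in a single place has been measured, so no step size is known from the data.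

Compound 4, `COc1ccc(C(O)C#CCOCc2ccc(SC)cc2)cc1`, is not yet measured. It differs from compound 1 by methoxy in place of fluoro on an aromatic carbon. With no measured step of this kind in the series, the expectation rests on compound 1 alone, whose number is 12000 nM in this assay, and on the weaker showing of the methoxy-bearing compound 2. The step from compound 1 to compound 4 is expected to be a 1.7-fold higher number from compound 1 to compound 4 (0.22 log units; within the scatter), that is, toward a somewhat higher number, though it may well fall within the scatter. For compound 4 the estimate in this assay is 20000 nM, with a range from 6000 nM to 70000 nM.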

Compound 4, half-maximal inhibitory concentration: > 100000 nM
Compound 4: a limit, no number (the forecaster's own chance of this, stated with the estimate: 5%); at least 5.0-fold (0.69 log units) between middle value and limit.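

In this assay compound 4 gives > 100000 nM, which is a limit of the assay and not a number. Among these compounds, on this aromatic carbon, para to a large group, methoxy in place of fluoro gives an at least 8.3-fold higher number from compound 1 to compound 4 (0.92 log units; beyond the scatter); this is the only step that isolates a single change, and it shows that the number responds to the group at this position, which the earlier compounds, differing from one another in more than one place, could not show. The step has no upper end that can be read, and compound 4 now sits at the same limit as one earlier compound: the limit of > 100000 nM in this assay, at which 2 of the 4 values shown sit.

The compounds shown leave open whether fluoro itself matters at this position or whether chloro, methyl or an amine there would stay close to compound 1, as only two groups can be compared at this place with the rest of the core held fixed. Also open, going by these compounds, is whether the same change carries the same penalty with the methylthio group of compound 1 replaced by a longer chain.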